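The compounds below may be only part of what the source reports. "The series", "measured", "known", "first", "only" and "open" are said of these compounds alone.

Measured compounds: compound 1 `CCN(Cc1cncs1)C(=O)COc1ccc(C)cc1` gives 1100 nM; compound 2 `CCN(Cc1cc[nH]c1)C(=O)COc1ccc(C)cc1` gives 21800 nM; compound 3 `CCN(Cc1ccsc1)C(=O)COc1ccc(C)cc1` gives 88 nM; all in an assay on HEK293 cells for agonist activity at transient receptor potential cation channel subfamily M member 8 (Homo sapiens), read by fluorescence and calcium flux, with a stated time of 15 min; a lower number here means that less compound is needed, a higher number that more compound is needed for the effect.

Compound 3 stands lowest of the three numbers; its nearest neighbour is compound 1, as seen in a 13-fold lower number from compound 1 to compound 3 (1.10 log units; beyond the scatter), and its furthest is compound 2, as seen in a 250-fold lower number from compound 2 to compound 3 (2.39 log units; beyond the scatter). Compound 4 `CCN(Cc1ccccn1)C(=O)COc1ccc(C)cc1` differs from compound 3 by pyridin-2-yl in place of thiophen-3-yl on a saturated chain carbon bound to an amide-type nitrogen. No measured step carries this exact change, but both ring replacements shown at this position, in a 13-fold lower number from compound 1 to compound 3 (1.10 log units; beyond the scatter) and a 250-fold lower number from compound 2 to compound 3 (2.39 log units; beyond the scatter), were large and favoured the thiophen-3-yl group, and the one other nitrogen-bearing five-membered ring without a donor, in compound 1, sat well above compound 3. The expected step is therefore a higher number beyond the scatter, estimated at around a 14-fold higher number from compound 3 to compound 4 (1.13 log units; beyond the scatter). Compound 4 is estimated at 1200 nM, between 250 nM and 6000 nM.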

Compound 4, half-maximal effective concentration: 16000 nM
Estimate against measurement, compound 4: 13-fold (1.12 log units) below; measured number outside the range, above it.
By their numbers in this assay, from the lowest: compound 3; then compound 1; then compounds 4 and 2 (each within the scatter of the next).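

In this assay, the first six-membered ring at this position, pyridin-2-yl, cannot be told apart from 1H-pyrrol-3-yl (a 1.4-fold lower number from compound 2 to compound 4 (0.13 log units; within the scatter)). It stands well clear of the thiophen-3-yl group (a 180-fold higher number from compound 3 to compound 4 (2.26 log units; beyond the scatter)) and of the 1,3-thiazol-5-yl group (a 15-fold higher number from compound 1 to compound 4 (1.16 log units; beyond the scatter)), so among these four compounds the two sulfur-bearing rings hold the two lowest numbers, with no compound against that pattern. Nothing measured here explains this order.

Going by these compounds, whether a phenyl or a pyridin-3-yl group on this saturated chain carbon would follow pyridin-2-yl or thiophen-3-yl stays open, as does the effect of a thiophen-2-yl group.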